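Benzodioxane substituent series: maximal response at the fatty acid receptor

The compounds below may be only part of what the source reports. "The series", "measured", "known", "first", "only" and "open" are said of these compounds alone.

Measured in a functional assay on HEK293 cells for agonist activity at Free fatty acid receptor 1 (Homo sapiens), read by fluorescence and calcium flux, with a stated time of 10 min; on this read-out lower numbers stand for smaller maximal responses and higher numbers for larger maximal responses:
compound 1 `CC#C[C@@H](CC(=O)O)c1ccc(OC[C@H]2COc3ccccc3O2)cc1`: 70%
compound 2 `CC#C[C@@H](CC(=O)O)c1ccc(OC[C@H]2COc3ccc(F)cc3O2)cc1`: 86%
compound 3 `CC#C[C@@H](CC(=O)O)c1ccc(OC[C@H]2COc3ccc(OC(F)(F)F)cc3O2)cc1`: 73%

Compound 3 stands second highest of the three; compound 1 lies nearest, within the scatter, while compound 2 lies furthest, beyond it. Compound 4 `CC#C[C@@H](CC(=O)O)c1ccc(OC[C@H]2COc3ccc(C#N)cc3O2)cc1` differs from compound 3 by cyano in place of trifluoromethoxy on an aromatic carbon. Among the compounds with values here, no measured step exchanges cyano. The steps that touch the same aromatic carbon are a number 3 percentage points higher from compound 1 to compound 3 (within the scatter), a number 16 percentage points higher from compound 1 to compound 2 (beyond the scatter) and a number 13 percentage points lower from compound 2 to compound 3 (beyond the scatter), so the substituent there moves the maximal response only modestly. For compound 4 the expected result in this assay is therefore a step of a number 5 percentage points higher from compound 3 to compound 4 (within the scatter), likely within or just beyond the scatter; the estimate for compound 4 is 78%, ranging from 66% to 90%.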

Compound 4, largest response reached (Emax), in percent of the reference or control that the assay uses: 60%
Compound 4: the middle estimate sits 18 percentage points above what was measured; measured number below the stated range.
By their numbers in this assay, from the lowest: compounds 4, 1 and 3 (each within the scatter of the next, the first and the last beyond it); then compound 2.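

At this aromatic carbon, cyano separates clearly from both fluorine-bearing substituents: a number 13 percentage points lower from compound 3 to compound 4 (beyond the scatter) and a number 26 percentage points lower from compound 2 to compound 4 (beyond the scatter). Against hydrogen the change stays small, a number 10 percentage points lower from compound 1 to compound 4 (within the scatter), so cyano, like trifluoromethoxy, remains within the scatter of the unsubstituted compound, and only fluoro stands clear of it. Nothing available accounts for the difference between these substituents. Still open, on these data alone, is whether the higher maximal response seen with fluoro extends to chloro, and how an amine or a methoxy group on the same carbon would read.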